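Capping the Free Hydroxy Group of Compound 2

The source may report more compounds than this note shows. Statements on the series, on what has been measured and on what is new or still open speak of the compounds shown alone.

Values in a functional assay on NCI-H520 cells (Homo sapiens) for cytotoxicity; a lower number here means a stronger inhibitor of growth, a higher number a weaker inhibitor of growth:
Compound 1 `COc1ccc(C2=C(c3ccc(SC)cc3)CC3CCCN3C2=O)cc1`: 800 nM
Compound 2 `CSc1ccc(C2=C(c3ccc(O)cc3)C(=O)N3CCCC3C2)cc1`: > 100000 nM, a limit of the assay

Compound 2 stands at the limit of > 100000 nM in this assay, at which 1 of the 2 values shown sits. Compound 3 `CSc1ccc(C2=C(c3ccc(OCC4CO4)cc3)C(=O)N3CCCC3C2)cc1` differs from it by one change: (oxiran-2-yl)methyl in place of hydrogen on an oxygen on an aromatic ring. Within the data shown here, one measured step bears on this, an at least 120-fold higher number from compound 1 to compound 2 (2.09 log units; beyond the scatter), a large step that put hydrogen in place of methyl on the same oxygen. Compound 3 again has no hydrogen there, though its group is not methyl, so a large step towards a lower number is expected in this assay. The expected step is an at least 66-fold lower number from compound 2 to compound 3 (1.82 log units; beyond the scatter). The estimate for compound 3 is 1500 nM, with an expected range of 300 nM to 10000 nM.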

Compound 3, concentration for 50% growth inhibition: 30 nM
Compound 3: middle estimate off by 50-fold (1.70 log units), on the high side, outside the stated range (below it).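

Compound 2 stands at a limit of the assay, > 100000 nM. Measured against that limit, (oxiran-2-yl)methyl on this oxygen gives an at least 3300-fold lower number from compound 2 to compound 3 (3.52 log units; beyond the scatter) in this assay. The same group also goes beyond methyl at this position, with a 27-fold lower number from compound 1 to compound 3 (1.43 log units; beyond the scatter), so what matters here is which group replaces the hydrogen, not only that the hydrogen is gone.

From the compounds shown here alone, whether the three-membered ring itself is needed for this gain remains open, as does how a 2,3-dihydroxypropyl group or a longer alkyl chain on the same oxygen would compare.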